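Three sulfonamides measured, a fourth awaiting its number

A few compounds are considered here, and "the series" means these few. Any claim that something is new, unique, unknown or untested is made for them only; others in the source may bear on it.

Compound 1, `CC(C)(C)c1ccc(CNCCCNS(=O)(=O)c2cc(C(F)(F)F)cc(C(F)(F)F)c2)cc1`, gives 2700 nM.
Compound 2, `O=S(=O)(NCCNCc1ccc(-c2ccccc2)cc1)c1cc(C(F)(F)F)cc(C(F)(F)F)c1`, gives 2800 nM.
Compound 3, `O=S(=O)(NCCCNCc1ccc(-c2ccccc2)cc1)c1cc(C(F)(F)F)cc(C(F)(F)F)c1`, gives 2500 nM.

All three numbers come from a functional assay on ASPC1 cells (Homo sapiens) for inhibition, read by MTT assay, with a stated time of 72 h; a higher number here means a weaker inhibitor of growth, a lower number a stronger inhibitor of growth. The three values sit close together: compound 2 has the highest number of the three, but its nearest neighbour, compound 1, and its furthest, compound 3, both lie within the usual scatter of it, so no order among them can be claimed.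

Compound 1 and compound 3 differ in one place. The change is tert-butyl in place of phenyl on an aromatic carbon. Its effect is a 1.1-fold higher number from compound 3 to compound 1 (0.03 log units; within the scatter), a step that is within the scatter.

The unmeasured compound is compound 4, `CC(C)(C)c1ccc(CNCCNS(=O)(=O)c2cc(C(F)(F)F)cc(C(F)(F)F)c2)cc1`. It is made from compound 2 by tert-butyl in place of phenyl on an aromatic carbon. Within the data shown here, this is the same change as the one from compound 3 to compound 1, with the same place, and it occurs twice among the compounds here. The cores of compound 2 and compound 3 are not the same, and the difference between the two cores is not broken down here.

Resting on the one earlier step, compound 4 is expected to stay close to compound 2, with an estimated 1.0-fold higher number from compound 2 to compound 4 (0.02 log units; within the scatter). The estimate for compound 4 is 2900 nM, between 1500 nM and 5600 nM, because the earlier step of a 1.1-fold higher number from compound 3 to compound 1 (0.03 log units; within the scatter) was within the scatter.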

Compound 4, concentration for 50% growth inhibition: 14000 nM
For compound 4 the middle estimate is 4.8-fold (0.68 log units) below the measured one; the whole stated range lies below it.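

In this assay, putting tert-butyl in place of phenyl on an aromatic carbon gives a 5.0-fold higher number from compound 2 to compound 4 (0.70 log units; beyond the scatter), so on this core the change makes a modest but real difference to the number, whereas compound 1 and compound 3 could not be told apart. The change therefore does not carry over in size from one core to the other, and its effect in this series cannot be read from one core and applied to the next: the same change on two cores in this assay, a 1.1-fold higher number (0.03 log units; within the scatter) from compound 3 to compound 1 and a 5.0-fold higher number (0.70 log units; beyond the scatter) from compound 2 to compound 4, 4.6-fold (0.67 log units) apart, beyond the scatter of two such steps What this does not show is which feature of the two cores lies behind the gap, since the difference between them is not broken down, and two pairs of compounds set a contrast rather than a rule for the series.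

The compounds shown leave open how the same change would behave on a core with a longer chain, and whether such a core would follow the pair of compound 3 and compound 1 or the pair of compound 2 and compound 4. They also leave open what an amine or a carboxylic acid would do on the aromatic carbon that carries the phenyl or the tert-butyl.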